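Propyl to butyl on the side chain of compound 3

The compounds below may be only part of what the source reports. "The series", "measured", "known", "first", "only" and "open" are said of these compounds alone.

Compound 1 `CCCCC1([C@@H](O)/C=C/C2[C@H](O)CC(=O)[C@@H]2CCCCCCC(=O)O)CCC1` gives 0.017 mg/kg in a functional assay on the whole organism (strain Hartley) for inhibition, with Cavia porcellus as the target, with stated times of 15 min and 2 min; a lower number here means that less compound is needed, a higher number that more compound is needed for the effect
Compound 2 `CCCCC1([C@H](O)/C=C/C2[C@H](O)CC(=O)[C@@H]2C/C=C\CCCC(=O)O)CCC1` gives 0.00154 mg/kg in this assay
Compound 3 `CCCC1([C@@H](O)/C=C/C2[C@H](O)CC(=O)[C@@H]2C/C=C\CCCC(=O)O)CCC1` gives 0.0467 mg/kg in this assay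

Compound 3 holds the highest number of the three, so it needs the most compound for the effect. Both other compounds lie lower, beyond the scatter, with compound 1 the nearer and compound 2 the further away.

Compound 4 `CCCCC1([C@@H](O)/C=C/C2[C@H](O)CC(=O)[C@@H]2C/C=C\CCCC(=O)O)CCC1` is still to be measured in this assay. It departs from compound 3 by methyl in place of hydrogen on a saturated chain carbon, three bonds along the chain from a saturated ring carbon. The chain thus goes from propyl to butyl.

Within the data shown here, no measured pair isolates this change, so the expectation rests on indirect evidence. Both butyl compounds lie below compound 3, with compound 1 at 0.017 mg/kg and compound 2 at 0.00154 mg/kg. These two also lie far apart, which leaves the size of the step open and calls for a wide range.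

A moderate fall in the number, beyond the scatter, is expected, and the estimated change is a 3.9-fold lower number from compound 3 to compound 4 (0.59 log units; beyond the scatter). For compound 4 the estimated value is 0.012 mg/kg, with an expected range from 0.003 mg/kg to 0.05 mg/kg.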

Compound 4, dose for half-maximal effect: 0.0484 mg/kg
Estimate against measurement, compound 4: 4.0-fold (0.61 log units) below; measured number inside the range.
By their numbers in this assay, from the lowest: compound 2; then compound 1; then compounds 3 and 4 (each within the scatter of the next).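

Propyl and butyl at this place, on a saturated chain carbon three bonds along the chain from a saturated ring carbon, cannot be told apart in this assay, with a 1.0-fold higher number from compound 3 to compound 4 (0.02 log units; within the scatter). Adding this methyl therefore does not account for the low numbers of the two other butyl compounds, and compound 4 instead shows a modest difference from the compound carrying 5-carboxypentyl in place of 5-carboxypent-1-en-1-yl, with a 2.8-fold higher number from compound 1 to compound 4 (0.45 log units; beyond the scatter). The largest gap in the series separates two compounds with the same atoms and bonds, with a stereocentre at a saturated chain carbon drawn R in compound 2 and S in compound 4, giving a 31-fold higher number from compound 2 to compound 4 (1.50 log units; beyond the scatter), although this reading carries a caveat about how the structures are drawn: the fact that one of compounds 2 and 4 is drawn with a defined configuration and the other without, at the place where they differ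

From the compounds shown here alone, whether a gap of this size between the two configurations also holds with propyl stays open. Equally open, going by these compounds, is how pentyl or a longer chain in place of butyl would read in this assay.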